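The source may report more compounds than this note shows. Statements on the series, on what has been measured and on what is new or still open speak of the compounds shown alone.

Compound 1 `COc1ccc(F)cc1CNCCCNc1ccnc2cc(Cc3ccc(C#N)cc3)ccc12` gives 9.47 in a physicochemical assay for acid dissociation.
Compound 2 `COc1cccc(CNCCCNc2ccnc3cc(Oc4ccccc4)ccc23)c1O` gives 9.28 in this assay.

Of the two numbers, that of compound 2 lies within the scatter of the number of compound 1, so the two cannot be told apart. Compound 3 `COc1ccc(-c2ccc3c(NCCCNCc4cccc(OC)c4O)ccnc3c2)cc1` differs from compound 2 by 4-methoxyphenyl in place of phenoxy on an aromatic carbon. Among the compounds with values here, no single-change step between measured compounds is available to guide the size of this move, and the change sits on the fused ring system, away from the amine chain. The author therefore expects no step beyond the scatter. For compound 3 the estimate is 9.3, between 9 and 9.6, with the expected step of a number 0.02 log units higher from compound 2 to compound 3 (within the scatter).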

Compound 3, acid dissociation constant: 9.47
Compound 3: middle estimate off by 0.17 log units, on the low side; measured number inside the range.
By their numbers in this assay, from the lowest: compounds 2, 1 and 3 (each within the scatter of the next).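

In this assay the only single-change step shown, 4-methoxyphenyl in place of phenoxy on this aromatic carbon, comes to a number 0.19 log units higher from compound 2 to compound 3 (within the scatter) and so cannot be told apart from repeat scatter. For this pair of groups, the position therefore shows no step beyond the scatter. No measured evidence bears on this result. The compounds shown leave open whether an amine or a carboxylic acid on this carbon would give a step beyond the scatter. They also leave open what a longer chain in place of the present amine chain would do.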